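The source may report more compounds than this note shows. Statements on the series, on what has been measured and on what is new or still open speak of the compounds shown alone.

Working notes on the series. In a functional assay, read by spectrophotometry, with a stated time of 20 min (a higher number here means a weaker inhibitor, a lower number a stronger inhibitor), compound 1 `O=C1C=C(Nc2ccc(Cl)cc2)CCC1` gives 71200 nM and compound 2 `CC(C)(C)OC(=O)N(C1=CC(=O)CCC1)c1ccc(Cl)cc1` gives 42600 nM. For the measured compounds named here, these are the only two numbers so far, and compound 2 stands within the scatter of compound 1.

Compound 3 `CC(=O)N(C1=CC(=O)CCC1)c1ccc(Cl)cc1` keeps the shared core and alters one group: methyl in place of tert-butoxy on a carbonyl carbon. In words, this is methyl in place of tert-butoxy on a carbonyl carbon, so tert-butoxycarbonyl becomes acetyl.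

Going by the values given here, one measured step bears on this change: a 1.7-fold lower number from compound 1 to compound 2 (0.22 log units; within the scatter), for tert-butoxycarbonyl in place of hydrogen on a nitrogen on an aromatic ring. Among the compounds with values here, no measured compound carries acetyl, so the evidence is indirect. No step beyond the scatter is expected in this assay, and the estimated change is a 1.2-fold higher number from compound 2 to compound 3 (0.07 log units; within the scatter). For compound 3, the estimated value is 50000 nM, with an expected range of 25000 nM to 100000 nM.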

Compound 3, half-maximal inhibitory concentration: 48000 nM
For compound 3 the middle estimate is 1.0-fold (0.02 log units) above the measured one, and the stated range covers the measured number.
By their numbers in this assay, from the lowest: compounds 2, 3 and 1 (each within the scatter of the next).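

In this assay, the change from tert-butoxy to methyl on a carbonyl carbon gives a 1.1-fold higher number from compound 2 to compound 3 (0.05 log units; within the scatter), so replacing five heavy atoms with one does not separate compound 2 from compound 3. Acetyl on the nitrogen also stays level with the free amide-type hydrogen of the parent, with a 1.5-fold lower number from compound 1 to compound 3 (0.17 log units; within the scatter), which means that neither tert-butoxycarbonyl nor acetyl gives a step from compound 1 beyond the scatter. No supporting measurement is available to explain this flat result.

The compounds shown leave open whether any group on this nitrogen can move the number beyond the scatter. A longer chain such as hexanoyl, or an acetyl carrying an amine or a carboxylic acid, would test this directly.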